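Heteroaryl swap at the central ring: furan to pyridine

The compounds below may be only part of what the source reports. "The series", "measured", "known", "first", "only" and "open" are said of these compounds alone.

Measured so far:
compound 1 `Oc1ccc(-c2cc(-c3ccco3)cc(-c3cccc(O)c3)n2)cc1` gives 2070 nM in a functional assay on DU-145 cells (Homo sapiens) for cytotoxicity, read by CCK-8 assay; a higher number here means a weaker inhibitor, a lower number a stronger inhibitor.
compound 2 `Oc1ccc(-c2cc(-c3ccoc3)cc(-c3cccc(O)c3)n2)cc1` gives 2700 nM in this assay.

Compound 2 has the highest of the two numbers in this assay; its nearest neighbour is compound 1, and the step of a 1.3-fold higher number from compound 1 to compound 2 (0.12 log units; within the scatter) lies within the scatter. Compound 3 `Oc1ccc(-c2cc(-c3ccccn3)cc(-c3cccc(O)c3)n2)cc1` differs from compound 2 by pyridin-2-yl in place of furan-3-yl on an aromatic carbon. Within the data shown here, the only measured step, the exchange of one furan isomer for the other from compound 1 to compound 2, bears on it loosely and was within the scatter. Among the measured compounds shown here, a five-membered ring giving way to a six-membered one has no precedent here. For compound 3 a number close to compound 2 is therefore expected, with the step of a 1.1-fold lower number from compound 2 to compound 3 (0.03 log units; within the scatter) not beyond the scatter, estimated at 2500 nM (range 1000 nM to 6500 nM).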

Compound 3, half-maximal inhibitory concentration: 1980 nM
Estimate against measurement, compound 3: 1.3-fold (0.10 log units) above, and the stated range covers the measured number.
By their numbers in this assay, from the lowest: compounds 3, 1 and 2 (each within the scatter of the next).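

Pyridin-2-yl on this carbon, opposite the ring nitrogen, gives a 1.4-fold lower number from compound 2 to compound 3 (0.13 log units; within the scatter) and a 1.0-fold lower number from compound 1 to compound 3 (0.02 log units; within the scatter) in this assay, so a six-membered aromatic ring sits here with no readable change from either furan. Neither ring size nor the exchange of ring oxygen for ring nitrogen separates compound 1, compound 2 and compound 3 in this read-out. Nothing at hand explains this level outcome.

From the compounds shown here alone, whether the position stays this flat with a different kind of group remains open, for instance a phenyl ring, a morpholine or a carboxylic acid. Going by these compounds, the pyridin-3-yl and pyridin-4-yl isomers also remain open.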